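The source may hold more compounds than are shown below. What is called first, only, known or untested is meant among the compounds shown, and "the series" means these compounds.

In a functional assay on MGC-803 cells (Homo sapiens) for antiproliferative activity, read by MTT assay, with a stated time of 72 h (a higher number here means a weaker inhibitor, a lower number a stronger inhibitor), compound 1, whose structure is `CCCSc1nc(N/N=C(\C)c2ccccc2O)c2nnn(Cc3ccco3)c2n1`, gives 4760 nM. Among the compounds with a measured number it stands alongside compound 3, whose structure is `C#CCSc1nc(N/N=C/c2ccc(N(C)C)cc2)c2nnn(Cc3ccccc3)c2n1` and which in this assay gives 7620 nM; the two values lie within the usual scatter of each other, so neither can be called the stronger inhibitor. Compound 2, whose structure is `CCCSc1nc(N/N=C/c2ccc3ccccc3c2)c2nnn(Cc3ccccc3)c2n1`, returns only a limit of the assay, > 64000 nM, and not a number. This is the situation described by the limit of > 64000 nM in this assay, at which 1 of the 3 values shown sits.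

Compound 4, whose structure is `CCCSc1nc(N/N=C(\C)c2ccccc2O)c2nnn(Cc3ccc(O)cc3)c2n1`, has not yet been measured in this assay. It differs from compound 1 in one place: 4-hydroxyphenyl in place of furan-2-yl on a saturated chain carbon bound to an aromatic nitrogen. Among the compounds with values here, since no measured pair of compounds shows exactly this exchange, there is no direct guide to its size. The expectation is that the step from compound 1 to compound 4 is small, a 1.1-fold lower number from compound 1 to compound 4 (0.05 log units; within the scatter), in either direction within the scatter rather than a clear move. Compound 4 is therefore estimated to give 4200 nM in this assay, with a plausible range from 1500 nM to 12000 nM.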

Compound 4, half-maximal inhibitory concentration: 7680 nM
Compound 4: the middle estimate sits 1.8-fold (0.26 log units) below what was measured; low and high end bracket the measured number.
By their numbers in this assay, from the lowest: compounds 1, 3 and 4 (each within the scatter of the next). At a limit, above all of these: compound 2.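

In this assay, within the data shown here, putting 4-hydroxyphenyl in place of furan-2-yl on a saturated chain carbon bound to an aromatic nitrogen gives a 1.6-fold higher number from compound 1 to compound 4 (0.21 log units; within the scatter), the first step at this position that can be read from a matched pair. The result shows that, in this pair, a five-membered aromatic ring with one hetero atom can be exchanged for a six-membered aromatic ring of carbon only, which also brings a hydrogen-bond donor, and the two numbers still lie within the scatter of each other. Nothing shown gives a reason for this outcome.

Going by these compounds, the exchange alters the ring and adds the hydroxyl in a single step, so the part played by each alone stays open, and compounds 2 and 3 differ from compounds 1 and 4 in more than one place and cannot settle it. On these data alone, it also stays open whether the same tolerance would hold with an amine or a carboxylic acid in place of the hydroxyl, or with a longer chain carrying the ring.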